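Switching the Aniline Substituent in a Styryl Sulfone Series

The source may hold more compounds than are shown below. What is called first, only, known or untested is meant among the compounds shown, and "the series" means these compounds.

Measured compounds:
compound 1, `COc1ccc(CS(=O)(=O)/C=C/c2c(OC)cc(O)cc2OC)cc1N`, 300 nM
compound 2, `COC(=O)CCNc1cc(CS(=O)(=O)/C=C/c2c(OC)cc(OC)cc2OC)ccc1OC`, 1000 nM

In a functional assay on K562 cells (Homo sapiens) for cytotoxicity, read by trypan blue exclusion, with a stated time of 96 h (a lower number here means a stronger inhibitor, a higher number a weaker inhibitor), compound 2 gives 1000 nM, the higher of the two numbers; compound 1 gives 300 nM. Compound 3, `COc1cc(OC)c(/C=C/S(=O)(=O)Cc2ccc(OC)c(NC(C(=O)O)c3ccc(F)cc3)c2)c(OC)c1`, has not yet been measured. It differs from compound 2 in one place: carboxy(4-fluorophenyl)methyl in place of 2-(methoxycarbonyl)ethyl on a nitrogen on an aromatic ring. Going by the values given here, no step between measured compounds bears on this change, so the expectation rests on compound 2 alone. A small shift toward a lower number, likely within the scatter, is expected, a 1.7-fold lower number from compound 2 to compound 3 (0.22 log units; within the scatter). For compound 3 the estimate in this assay is 600 nM, with a range from 200 nM to 2500 nM.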

Compound 3, half-maximal inhibitory concentration: 80 nM
Estimate against measurement, compound 3: 7.5-fold (0.88 log units) above, and the stated range ends above it.
By their numbers in this assay, from the lowest: compound 3; then compound 1; then compound 2.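

In this assay, carboxy(4-fluorophenyl)methyl in place of 2-(methoxycarbonyl)ethyl on a nitrogen on an aromatic ring gives a 13-fold lower number from compound 2 to compound 3 (1.10 log units; beyond the scatter). Going by these compounds alone, this is the first change in a single place, and it shows that the substituent on this nitrogen strongly affects the number and that a group carrying an aromatic ring is tolerated there. Nothing available explains the size of this step.

The change swaps the ester chain for a group with both a carboxylic acid and a 4-fluorophenyl ring, so the compounds shown do not separate these two parts. Going by these compounds, whether carboxymethyl or benzyl on that nitrogen would give a similar number remains open.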